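Removing the pyridin-2-yl group from compound 1

The source may report more compounds than this note shows. Statements on the series, on what has been measured and on what is new or still open speak of the compounds shown alone.

Compound 1 `c1ccc(-c2cccc3c2CCC3c2ncc[nH]2)nc1` gives 53% in a functional assay on CHO cells for agonist activity at Alpha-1A adrenergic receptor (Homo sapiens), read by FLIPR and calcium flux; a higher number here means a larger maximal response, a lower number a smaller maximal response. Compound 2 `COc1c(C)ccc2c1CCC2c1ncc[nH]1` gives 40%. Compound 3 `COc1cccc2c1CCC2c1ncc[nH]1` gives 65%.

Among these three, compound 1 stands second highest; compound 3 lies above it by a number 12 percentage points higher from compound 1 to compound 3 (beyond the scatter), while compound 2 sits lower. Compound 4 `c1ccc2c(c1)CCC2c1ncc[nH]1` differs from compound 1 thus: hydrogen in place of pyridin-2-yl on an aromatic carbon. Among the measured compounds shown here, the step that bears on this is the one from compound 1 to compound 3, where methoxy in place of pyridin-2-yl at the same site brought a number 12 percentage points higher from compound 1 to compound 3 (beyond the scatter), a modest rise. The step from compound 2 to compound 3, a number 25 percentage points higher from compound 2 to compound 3 (beyond the scatter), concerns another site. Taking hydrogen in place of pyridin-2-yl as a further trimming at that site, compound 4 is expected to give about 62%, within 42% to 82%. The expected step is a number 9 percentage points higher from compound 1 to compound 4 (within the scatter).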

Compound 4, largest response reached (Emax), in percent of the reference or control that the assay uses: 54%
Compound 4: the middle estimate sits 8 percentage points above what was measured; measured number inside the range.
By their numbers in this assay, from the lowest: compound 2; then compounds 1 and 4 (each within the scatter of the next); then compound 3.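

In this assay, hydrogen in place of pyridin-2-yl gives a number 1 percentage points higher from compound 1 to compound 4 (within the scatter), so compound 1 and compound 4 cannot be told apart and the whole pyridin-2-yl group can go without a readable difference. Methoxy alone stands apart at this site, since hydrogen in its place gives a number 11 percentage points lower from compound 3 to compound 4 (beyond the scatter). Nothing available here explains this. On these data alone, it remains open whether an ethoxy group or an amine at this site would match compound 3, and whether a methyl group elsewhere on the ring would matter without methoxy present.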